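Swapping Butyl for a Methoxy-Bearing Group

The source may hold more compounds than are shown below. What is called first, only, known or untested is meant among the compounds shown, and "the series" means these compounds.

Compound 1 `CC(C)(C)[C@@H](O)C(=O)N1CCS[C@H]1C(=O)NCc1cc(Cl)ccc1-n1cnnn1`: 5.2 10^-6 cm/s
Compound 2 `O=C(NCc1cc(Cl)ccc1-n1cnnn1)[C@@H]1[C@@H]2C[C@@H]2CN1C(=O)[C@H](O)Cc1ccccn1`: 0.62 10^-6 cm/s
Compound 3 `CCCC[C@@H](O)C(=O)N1C[C@H]2C[C@H]2[C@H]1C(=O)NCc1cc(Cl)ccc1-n1cnnn1`: 33 10^-6 cm/s

In an ADME assay on Caco-2 cells (Homo sapiens) for permeability, read by LC-MS, in the apical to basolateral direction, with a stated time of 60 min, at pH 6.5 (on this read-out higher numbers stand for higher permeability and lower numbers for lower permeability), compound 3 gives the highest of the three numbers, clear of the other two. Compound 4 `COC(C)(C)[C@@H](O)C(=O)N1C[C@H]2C[C@H]2[C@H]1C(=O)NCc1cc(Cl)ccc1-n1cnnn1` carries 1-methoxy-1-methylethyl in place of butyl on a saturated chain carbon bound to a carbonyl carbon and an oxygen on a saturated carbon. Among the compounds with values here, the only measured step, with propyl in place of pyridin-2-yl, is large: a 53-fold higher number from compound 2 to compound 3 (1.73 log units; beyond the scatter). It shows that a group change on this chain can move the number far, but it involves different groups, so it is only a loose guide. With compound 3 at the top, a moderate drop is expected, the estimated 2.5-fold lower number from compound 3 to compound 4 (0.40 log units; beyond the scatter). For compound 4 the expected value is 13 10^-6 cm/s, estimated to lie from 4 10^-6 cm/s to 32 10^-6 cm/s.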

Compound 4, apparent permeability: 3.5 10^-6 cm/s
Estimate against measurement, compound 4: 3.7-fold (0.57 log units) above, outside the stated range (below it).
By their numbers in this assay, from the lowest: compound 2; then compounds 4 and 1 (each within the scatter of the next); then compound 3.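

Changing butyl to 1-methoxy-1-methylethyl in this assay gives a 9.4-fold lower number from compound 3 to compound 4 (0.97 log units; beyond the scatter), so this position responds strongly to a change between two groups without a ring, not only to the loss of a ring-bearing group. The same group in place of (pyridin-2-yl)methyl gives a 5.6-fold higher number from compound 2 to compound 4 (0.75 log units; beyond the scatter), which places compound 4 between compound 2 and compound 3 on their shared core. Nothing measured here explains these shifts.

Going by these compounds, the branching and the oxygen arrive together, so their separate contributions remain open. An unbranched 3-methoxypropyl group and a branched, oxygen-free isopentyl group on this core would pull them apart.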